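Changing One Sulfonyl Group and Following Cell Tolerance

A few compounds are considered here, and "the series" means these few. Any claim that something is new, unique, unknown or untested is made for them only; others in the source may bear on it.

Going by the values given here, in an ADME assay on MT4 cells (Homo sapiens) for cytotoxicity, with a stated time of 5 days (a higher number here means that more compound is tolerated, a lower number that less compound is tolerated), compound 1 (`O=C(CCl)Nc1ccc(Cl)cc1NS(=O)(=O)c1c(F)cccc1F`) gives 175000 nM, the only exact number available so far. Compound 2 (`O=c1[nH]c2ccc(Cl)cc2n1S(=O)(=O)c1c(Cl)cccc1Cl`) is reported only as a limit, > 331000 nM. Compound 1 therefore has no second exact number to be ranked against.

The next compound, compound 3 (`O=C(CCl)Nc1ccc(Cl)cc1NS(=O)(=O)c1cc(Cl)cc(Cl)c1`), keeps the core of compound 1 and alters a single group. The change is 3,5-dichlorophenyl in place of 2,6-difluorophenyl on a sulfonyl sulfur, with 3,5-dichlorophenyl in place of 2,6-difluorophenyl on a sulfonyl sulfur. Everything else in the molecule stays the same, so any shift in this assay can be traced to this one swap.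

Among the compounds with values here, no measured pair here isolates a swap of this kind, so the forecast is a judgement anchored only on compound 1 at 175000 nM. A modest move toward less compound being tolerated is expected, a 2.2-fold lower number from compound 1 to compound 3 (0.34 log units; beyond the scatter), and a result within the usual scatter would be no surprise. For compound 3 the estimated value is 80000 nM, with an expected range of 20000 nM to 300000 nM.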

Compound 3, half-maximal cytotoxic concentration: > 291000 nM
Compound 3: no number, only a limit; the forecaster's own chance of this, stated with the estimate: 20%; middle value at least 3.6-fold (0.56 log units) from the limit.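

In this assay compound 3 is reported only as a limit, not as an exact number: the limit of > 291000 nM in this assay, at which 1 of the 3 values shown sits. The swap reads as an at least 1.6-fold higher number from compound 1 to compound 3 (0.22 log units; that floor lies within the scatter) for 3,5-dichlorophenyl in place of 2,6-difluorophenyl on a sulfonyl sulfur whose other neighbour is the sulfonamide nitrogen. Going by these compounds, what this adds is a direction that compound 1 alone could not give: at this place the swap brings no fall in the number, so cell tolerance survives the change of group, though the floor of the step stays within the scatter and the true size of any rise remains unknown.

Two things change at once in this swap, the halogen and where it sits on the ring, so the compounds shown leave open whether either one alone would give the same reading, as a 2,6-dichlorophenyl or a 3,5-difluorophenyl group could show. Also open, on these data alone, is how a plain phenyl, a methyl group or a pyridine ring would read on this sulfonyl sulfur, and how far the true value of compound 3 lies past its limit.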